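The source may hold more compounds than are shown below. What is called first, only, known or untested is meant among the compounds shown, and "the series" means these compounds.

Measured so far:
compound 1 `C=CCn1c(=O)/c(=C\c2cccc(C)c2)[nH]c(=O)/c1=C\c1ccccc1OC` — 22700 nM
compound 2 `C=CCn1c(=O)/c(=C\c2cc(OC)c(OC)c(OC)c2)[nH]c(=O)/c1=C\c1cccc(Br)c1` — "not active" (no number reported)
compound 3 `COc1ccccc1/C=c1/[nH]c(=O)/c(=C\c2cccc(Cl)c2Cl)[nH]c1=O` — "not active" (no number reported)

In a functional assay on A549 cells (Homo sapiens) for cytotoxicity, read by CCK-8 assay, with a stated time of 72 h (a higher number here means a weaker inhibitor, a lower number a stronger inhibitor), compound 1 gives 22700 nM, the only numerical result in the series. Compound 2 is reported as "not active" (no number reported), with no number. Compound 3 likewise is reported as "not active" (no number reported). For the measured compounds named here, compound 1 therefore stands as the one compound with a measured concentration, a weak one, and no step between two measured compounds is available to calibrate the effect of a change on the shared core.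

Compound 4 `C=CCn1c(=O)/c(=C\c2cc(Br)ccc2F)[nH]c(=O)/c1=C\c1ccccc1OC` differs from compound 1 in one place: 5-bromo-2-fluorophenyl in place of 3-methylphenyl on a double-bonded chain carbon bound to an aromatic carbon. With two of three measured compounds returning no number at all, the expectation for this change is a step from compound 1 to compound 4 of a 1.5-fold higher number from compound 1 to compound 4 (0.19 log units; within the scatter), toward weaker inhibition rather than stronger, though it could also fall within the scatter. Compound 4 is expected at about 35000 nM, in the range 10000 nM to 120000 nM, with a real chance that only an inactive result is reported.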

Compound 4, half-maximal inhibitory concentration: "not active" (no number reported)
No number was reported for compound 4; the estimate stays without a comparison.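

For the compounds shown here, compound 4 is reported as not active, with no number, so no step from compound 1 can be read. No evidence bears on this result. The compounds shown leave open how 5-bromo-2-fluorophenyl and 3-methylphenyl compare on the shared core in this assay as numbers.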